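A few compounds are considered here, and "the series" means these few. Any claim that something is new, unique, unknown or untested is made for them only; others in the source may bear on it.

In an ADME assay on the whole organism with Oryza sativa as the target, tested at 0.1 uM (a lower number here means a stronger effect, a higher number a weaker effect of the compound at the concentration tested), compound 2 `C[C@@H](NC(=O)Nc1ccccc1C(C)(C)C)c1ccccc1` gives 100%, and the other two numbers sit within the scatter of it: compound 3 `C[C@H](NC(=O)Nc1ccccc1C(C)(C)C)c1ccccc1` gives 101% and compound 1 `CC(C)c1ccccc1NC(=O)N[C@H](C)c1ccccc1` gives 103%. The two measured steps are both small. There is a number 3 percentage points lower from compound 1 to compound 2 (within the scatter), and there is a number 1 percentage points higher from compound 2 to compound 3 (within the scatter), the second resting on (the fact that compounds 2 and 3 differ only in the configuration as drawn). Compound 4 `COc1ccccc1NC(=O)N[C@H](C)c1ccccc1` differs from compound 2 by methoxy in place of tert-butyl on an aromatic carbon. Among the compounds with values here, neither measured step touches the group on the aromatic carbon, so no step bears directly on this change; what the three compounds show is only that the read-out has stayed close from one to the next under a change on the saturated chain carbon and under a change of configuration. On that basis the step of no change at the digits printed from compound 2 to compound 4 (within the scatter) is expected to be none beyond the scatter. Compound 4 is therefore estimated to give 100%, with a range from 88% to 110%.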

Compound 4, a percentage reported as activity, at one concentration (the size of the read-out at that concentration, not a potency): 100%
The estimate for compound 4 equals the measured number at the digits printed; low and high end bracket the measured number.
By their numbers in this assay, from the lowest: compounds 2, 4, 3 and 1 (each within the scatter of the next).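

In this assay, compound 4 is the first of these compounds to show a change at the group on the aromatic carbon, where the others carry a saturated carbon group. Methoxy in place of tert-butyl gives no change at the digits printed from compound 2 to compound 4 (within the scatter), and methoxy in place of isopropyl gives a number 3 percentage points lower from compound 1 to compound 4 (within the scatter), so this position tolerates an oxygen-linked group, with one hydrogen-bond acceptor entering, without the read-out leaving the scatter. Nothing measured here accounts for why the read-out holds across this change.

Since all four compounds lie within the scatter of one another, none of them shows a change at this position that moves the read-out at all. On these data alone, whether an amine, a carboxylic acid or a longer chain on this aromatic carbon would do so remains open.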